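The compounds below may be only part of what the source reports. "The series", "measured", "known", "first", "only" and "open" are said of these compounds alone.

Compound 1 `O=[N+]([O-])c1ccc(-c2nn(-c3ccccc3)cc2C(Nc2nc3ccccc3s2)c2c(O)ccc3ccccc23)cc1`: 6810 nM
Compound 2 `Oc1ccc2ccccc2c1C(Nc1nc2ccccc2s1)c1cn(-c2ccccc2)nc1-c1ccc(I)cc1`: 6590 nM
Compound 3 `COc1ccc2nc(NC(c3cn(-c4ccccc4)nc3-c3cccc([N+](=O)[O-])c3)c3c(O)ccc4ccccc34)sc2c1`: 6140 nM

All three compounds were tested in a functional assay on HeLa cells (Homo sapiens) for antiproliferative activity, read by MTT assay, with a stated time of 48 h; on this read-out higher numbers stand for weaker inhibition and lower numbers for stronger inhibition. Compound 1 and compound 2 share the same core; compound 2 differs from compound 1 by iodo in place of nitro on an aromatic carbon. That change produced a 1.0-fold lower number from compound 1 to compound 2 (0.01 log units; within the scatter), a step that stays within the scatter of repeated measurements, so the two values cannot be told apart.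

Compound 3 is built on a different core, and the difference between the two cores is not broken down here. In this assay compound 3 sits among the other two values, all three lying within the scatter of one another.

Compound 4 `COc1ccc2nc(NC(c3cn(-c4ccccc4)nc3-c3cccc(I)c3)c3c(O)ccc4ccccc34)sc2c1` is the unmeasured partner of compound 3, differing from it by iodo in place of nitro on an aromatic carbon. This is the same kind of change as that from compound 1 to compound 2, though the place differs: in compound 2 the iodo stands para to a large group, whereas in compound 4 it stands meta to a large group.

Because the earlier instance gave a 1.0-fold lower number from compound 1 to compound 2 (0.01 log units; within the scatter), compound 4 is expected to show a comparably small step, a 1.0-fold higher number from compound 3 to compound 4 (0.00 log units; within the scatter). Compound 4 is therefore estimated at 6200 nM in this assay, with the likely range 3000 nM to 12500 nM.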

Compound 4, half-maximal inhibitory concentration: 6240 nM
Compound 4: the middle estimate sits 1.0-fold (0.00 log units) below what was measured; measured number inside the range.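

In this assay, putting iodo in place of nitro gave a 1.0-fold higher number from compound 3 to compound 4 (0.01 log units; within the scatter), and the step matches the one seen earlier on the other core: the same change on two cores in this assay, a 1.0-fold lower number (0.01 log units; within the scatter) from compound 1 to compound 2 and a 1.0-fold higher number (0.01 log units; within the scatter) from compound 3 to compound 4, 1.1-fold (0.02 log units) apart, within the scatter of two such steps. Across these two pairs, then, the exchange of nitro for iodo carries from one core to the other without a change that can be read, even though the group stands at a different place on the ring in the two pairs. This does not show that the two groups are interchangeable in general, since it rests on two pairs in a single cell assay, and core and place differ together, so neither can be judged alone.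

The compounds shown leave open whether a group of another kind on that phenyl ring, such as an amine or a carboxylic acid, would move the number beyond the scatter. They also leave open what the methoxy group on compound 3 and compound 4 contributes on its own; no pair shown differs in that group alone.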